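Ethyl to methyl on the amide of compound 3

A few compounds are considered here, and "the series" means these few. Any claim that something is new, unique, unknown or untested is made for them only; others in the source may bear on it.

Measured in a functional assay on the whole organism with Rattus norvegicus as the target, at a dose of 20 mg/kg by the oral route; on this read-out higher numbers stand for more inhibition at the one dose given (going by the name of the read-out) and lower numbers for less inhibition:
- compound 1 `O=C(/C=C1\CCc2cc(Cl)ccc21)NC1CC1`: 29%
- compound 2 `NC(=O)/C=C1\CCc2c(F)cccc21`: 34%
- compound 3 `CCNC(=O)/C=C1\CCc2ccc(F)cc21`: 63%

Among the three measured compounds, compound 3 stands highest in this assay. Its value in this assay sits above that of compound 2 by a margin beyond the usual scatter, and above that of compound 1 by a still wider margin, also beyond the scatter. Compound 1 and compound 2 differ from compound 3 in more than one place, so their values show only where they lie, not what any single change does.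

Compound 4 `CNC(=O)/C=C1\CCc2ccc(F)cc21` is the next compound to be measured in this assay. It differs from compound 3 by a single change: hydrogen in place of methyl on a saturated chain carbon bound to an amide-type nitrogen. The ethylcarbamoyl group becomes a methylcarbamoyl group and nothing else moves.

Compound 4 is expected to land close to compound 3, with a small step of a number 11 percentage points lower from compound 3 to compound 4 (beyond the scatter) that may fall within the scatter or slightly below. The estimate for compound 4 is 52%, with a range from 30% to 72%.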

Compound 4, a percentage reported as inhibition, in the whole organism at one dose (the size of the read-out at that dose, not a potency): 38%
Beside the measured number, compound 4's estimate is 14 percentage points above it; the measured number falls inside the stated range.
By their numbers in this assay, from the lowest: compounds 1, 2 and 4 (each within the scatter of the next); then compound 3.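

In this assay, the change from ethylcarbamoyl to methylcarbamoyl gives a number 25 percentage points lower from compound 3 to compound 4 (beyond the scatter). Within the data shown here, this is the first comparison in the set with everything else held fixed, and it shows that this saturated chain on the amide nitrogen is not indifferent: the loss of one methyl alone gives a step beyond the scatter, which the earlier compounds, differing in more than one place, could not show. No measurement at hand accounts for the step.

The compounds shown leave open whether a longer chain such as propyl, or a branched group such as isopropyl, would stand above or below ethyl on the same core. They also leave open whether the same step would appear with chlorine in place of the fluorine, or at doses other than the one given.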